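The source may report more compounds than this note shows. Statements on the series, on what has been measured and on what is new or still open speak of the compounds shown alone.

Compound 3 `CCOC(=O)C1=CCCCC1S(=O)(=O)Cc1ccc(Cl)cc1` stands second highest of the three numbers in a functional assay on RAW264.7 cells (Mus musculus), read by fluorescence (on this read-out lower numbers stand for stronger inhibition and higher numbers for weaker inhibition), where compound 3 gives 101 nM. Compound 1 `CCOC(=O)C1=CCCCC1S(=O)(=O)Cc1ccc(Cl)cc1F` sits closest, giving 104 nM, and the step of a 1.0-fold lower number from compound 1 to compound 3 (0.01 log units; within the scatter) lies within the scatter. Compound 2 `CCOC(=O)C1=CCCCC1S(=O)(=O)Cc1cccc(Cl)c1` sits furthest, giving 14 nM, and the step of a 7.2-fold higher number from compound 2 to compound 3 (0.86 log units; beyond the scatter) is beyond the scatter. Compound 4 `CCOC(=O)C1=CCCCC1S(=O)(=O)Cc1ccc(Cl)c(Cl)c1` differs from compound 3 by chloro in place of hydrogen on an aromatic carbon, so compound 4 carries the chloro arrangement of compound 2 together with that of compound 3. The step of a 7.2-fold higher number from compound 2 to compound 3 (0.86 log units; beyond the scatter) bears on this directly, whereas a 1.0-fold lower number from compound 1 to compound 3 (0.01 log units; within the scatter) shows an added halogen at another position changing nothing. A lower number is therefore expected for compound 4, with a step of a 4.0-fold lower number from compound 3 to compound 4 (0.61 log units; beyond the scatter). The estimate for compound 4 is 25 nM, ranging from 8 nM to 80 nM.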

Compound 4, half-maximal inhibitory concentration: 53 nM
For compound 4 the middle estimate is 2.1-fold (0.33 log units) below the measured one; the measured number falls inside the stated range.
By their numbers in this assay, from the lowest: compound 2; then compounds 4, 3 and 1 (each within the scatter of the next).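

In this assay, chloro in place of hydrogen on the aromatic carbon ortho to the chloro group of compound 3 gives a 1.9-fold lower number from compound 3 to compound 4 (0.28 log units; within the scatter) and so stays within the scatter. The same kind of change on compound 2 gives a 3.8-fold higher number from compound 2 to compound 4 (0.58 log units; beyond the scatter) and lies beyond the scatter, so the low number of compound 2 does not survive the second chloro group. Going by these compounds, whether a methoxy group or a nitrile on this carbon would behave as chloro does remains open. Nothing available explains why the two chloro groups combine this way.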